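The compounds below may be only part of what the source reports. "The series", "measured", "known", "first", "only" and "open" are said of these compounds alone.

Measured compounds:
- compound 1, `COc1cc(-c2noc(-c3ccc(NC(=O)OC(C)(C)C)cc3)n2)cc(OC)c1OC`: 1600 nM
- compound 2, `COc1cc(-c2noc(-c3ccc(N)cc3)n2)cc(OC)c1OC`: 800 nM
- compound 3, `COc1cc(-c2noc(-c3cccc(N)c3)n2)cc(OC)c1OC`: 7000 nM

All three were tested in a functional assay on cells (Splenocyte, Mus musculus, strain BALB/c) for inhibition, read by scintillation counting and thymidine incorporation, with stated times of 48 h and 8 h; on this read-out higher numbers stand for weaker inhibition and lower numbers for stronger inhibition. Compound 3 gives the highest of the three numbers, so it is the weakest inhibitor of this small set; compound 1 stands nearest to it and compound 2 furthest. Two steps connect the measured compounds. Taking the tert-butoxycarbonyl off the ring nitrogen gave a 2.0-fold lower number from compound 1 to compound 2 (0.30 log units; within the scatter), too small to count. Moving the amino group from 4-aminophenyl to 3-aminophenyl gave an 8.8-fold higher number from compound 2 to compound 3 (0.94 log units; beyond the scatter), a clear loss of inhibition.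

Compound 4, `CCc1ccc(-c2nc(-c3cc(OC)c(OC)c(OC)c3)no2)cc1`, has not yet been measured. Its change from compound 3 is 4-ethylphenyl in place of 3-aminophenyl on an aromatic carbon. Among the compounds with values here, no measured step swaps an amino group for an ethyl group, so the known steps bear on it only in part. The step from compound 2 to compound 3 shows that the 4-aminophenyl arrangement gives a lower number than 3-aminophenyl, and compound 4 returns to a group placed as in 4-ethylphenyl. As far as these compounds go, the loss of the donor and acceptor is untested, which widens the uncertainty.

Compound 4 is therefore expected to give 2500 nM, within 600 nM to 10000 nM. That expectation amounts to a 2.8-fold lower number from compound 3 to compound 4 (0.45 log units; beyond the scatter).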

Compound 4, half-maximal inhibitory concentration: > 50000 nM
Compound 4: no number, only a limit (the forecaster's own chance of this, stated with the estimate: 10%); at least 20-fold (1.30 log units) between middle value and limit.
By their numbers in this assay, from the lowest: compounds 2 and 1 (each within the scatter of the next); then compound 3. At a limit, above all of these: compound 4.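

In this assay compound 4 stands at a limit, not at a number: the limit of > 50000 nM in this assay, at which 1 of the 4 values shown sits.

Within the data shown here, until now the substituent on this phenyl ring had changed only on its nitrogen or in where the amino group sat, and every compound gave a number; compound 4 is the first of the set with no nitrogen there, and replacing the amino group of the 4-aminophenyl with ethyl gives an at least 62-fold higher number from compound 2 to compound 4 (1.79 log units; beyond the scatter), while replacing the (tert-butoxycarbonyl)amino group with ethyl gives an at least 31-fold higher number from compound 1 to compound 4 (1.49 log units; beyond the scatter). Even the less favourable 3-aminophenyl compares well with 4-ethylphenyl, with an at least 7.1-fold higher number from compound 3 to compound 4 (0.85 log units; beyond the scatter), so among these four compounds all those with a nitrogen-bearing group on the ring give a number and the ethyl compound does not, with none going against this.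

The compounds shown leave open whether the loss comes from removing the amino group or from adding the ethyl chain, a question that a plain unsubstituted phenyl, a methyl or a hydroxyl on the same ring could help settle. As far as these compounds go, how far compound 4 really lies past its limit also remains unknown.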